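A few compounds are considered here, and "the series" means these few. Any claim that something is new, unique, unknown or untested is made for them only; others in the source may bear on it.

Compound 1 `CCOC(=O)c1cc2ccc(OCCCn3cc(CNC(=O)CCCCC4CCSS4)nn3)cc2oc1=O` carries an ethoxycarbonyl group on its coumarin-like core and a three-carbon linker to the triazole. In a functional assay on PC-12 cells (Rattus norvegicus) for cytotoxicity, read by MTT assay, with stated times of 3 h and 2 h, tested at 50 uM (a higher number here means a stronger effect of the compound at the concentration tested, a lower number a weaker effect), compound 1 gives 49.2%. Compound 2 `O=C(CCCCC1CCSS1)NCc1cn(CCCOc2ccc3cc(-c4ccccc4)c(=O)oc3c2)nn1` differs from it only by phenyl in place of ethoxycarbonyl on an aromatic carbon, and in this assay compound 2 gives 23.1%, a step of a number 26.1 percentage points lower from compound 1 to compound 2 (beyond the scatter). Compound 3 `CCOC(=O)c1cc2ccc(OCCCCCn3cc(CNC(=O)CCCCC4CCSS4)nn3)cc2oc1=O` keeps the ethoxycarbonyl group but has a longer five-carbon linker; how its core differs from that of compound 1 is not broken down here. In this assay compound 3 gives 40.7%, and its gap to compound 1 lies within the usual scatter, so the two cannot be told apart. Compound 4 `O=C(CCCCC1CCSS1)NCc1cn(CCCCCOc2ccc3cc(-c4ccccc4)c(=O)oc3c2)nn1` is related to compound 3 by phenyl in place of ethoxycarbonyl on an aromatic carbon, the same change at the same place as from compound 1 to compound 2. Because that earlier step was a number 26.1 percentage points lower from compound 1 to compound 2 (beyond the scatter), a step of about a number 24.7 percentage points lower from compound 3 to compound 4 (beyond the scatter) is expected here, resting on that single measured pair. Compound 4 is therefore expected to give about 16% in this assay, roughly between 4% and 30%.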

Compound 4, a percentage reported as activity, at one concentration (the size of the read-out at that concentration, not a potency): 17.7%
Compound 4: middle estimate off by 1.7 percentage points, on the low side; low and high end bracket the measured number.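

In this assay, phenyl in place of ethoxycarbonyl on an aromatic carbon again brings a number 23 percentage points lower from compound 3 to compound 4 (beyond the scatter). The two steps match in direction and in size: the same change on two cores in this assay, a number 26.1 percentage points lower (beyond the scatter) from compound 1 to compound 2 and a number 23 percentage points lower (beyond the scatter) from compound 3 to compound 4, 3.1 percentage points apart, within the scatter of two such steps. On these two cores, then, the change carries over, and the step measured on one core gave a fair guide to the step on the other; this does not show that it would carry over to a core of a different kind, and two pairs alone give no reason why the number falls.

As far as these compounds go, only ethoxycarbonyl and phenyl appear at this place, so how a carboxylic acid, an amine or a small methyl group would behave there remains open. Also open, from the compounds shown here alone, is whether the same step would hold with a still longer chain between the core and the triazole, or with a shorter one.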